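Fluorine on the benzyl group: an expected flat step

The source may report more compounds than this note shows. Statements on the series, on what has been measured and on what is new or still open speak of the compounds shown alone.

Of the compounds shown here, three have so far been tested in a functional assay on 3T3-L1 cells (Mus musculus) for inhibition, with a stated time of 20 min, tested at 20 uM; on this read-out higher numbers stand for more inhibition at the one concentration tested (going by the name of the read-out) and lower numbers for less inhibition. Compound 1 `Cc1ccc(S(=O)(=O)n2c(CN(Cc3cn(Cc4ccc(F)cc4F)nn3)S(C)(=O)=O)c(C)c3ccccc32)cc1` gives -20.8%. Compound 2 `Cc1ccc(S(=O)(=O)N(Cc2cn(Cc3ccccc3)nn2)Cc2c(-c3ccccc3)c3ccccc3n2S(=O)(=O)c2ccc(C)cc2)cc1` gives 0.03%, and compound 3 `Cc1ccc(S(=O)(=O)N(Cc2cn(Cc3ccccc3)nn2)Cc2c(C)c3ccccc3n2S(=O)(=O)c2ccc(C)cc2)cc1` gives -5.9%. For the measured compounds named here, compound 3 thus holds the second highest of the three numbers; its nearest neighbour is compound 2, and the one measured step between them, a number 5.9 percentage points lower from compound 2 to compound 3 (within the scatter), lies within the scatter. Compound 1 is further away, beyond the scatter, but it differs from compound 3 in more than one place, so the two values only show that both sit near or below zero.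

Compound 4 `Cc1ccc(S(=O)(=O)N(Cc2cn(Cc3ccc(F)cc3F)nn2)Cc2c(C)c3ccccc3n2S(=O)(=O)c2ccc(C)cc2)cc1` has not yet been measured. It differs from compound 3 in one place: 2,4-difluorophenyl in place of phenyl on a saturated chain carbon bound to an aromatic nitrogen. Going by the values given here, no measured step changes the benzyl group alone, so nothing bears directly on this change; the only measured step, methyl in place of phenyl, was within the scatter. Compound 1 carries the same 2,4-difluorobenzyl together with a second change and sits at the low end of the three values. For compound 4 the expected step is a number 2.1 percentage points lower from compound 3 to compound 4 (within the scatter), that is, none beyond the scatter. Compound 4 is therefore estimated at -8%, within a range from -25% to 10%.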

Compound 4, a percentage reported as inhibition, at one concentration (the size of the read-out at that concentration, not a potency): -22%
Compound 4: middle estimate off by 14 percentage points, on the high side; measured number inside the range.
By their numbers in this assay, from the lowest: compounds 4 and 1 (each within the scatter of the next); then compounds 3 and 2 (each within the scatter of the next).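

In this assay, replacing benzyl with 2,4-difluorobenzyl gives a number 16.1 percentage points lower from compound 3 to compound 4 (beyond the scatter), the first step beyond the scatter among these compounds, so this position on a saturated chain carbon bound to an aromatic nitrogen can shift the read-out, here towards less inhibition. The other new step, a number 1.2 percentage points lower from compound 1 to compound 4 (within the scatter), swaps methyl for 4-methylphenyl on a sulfonyl sulfur and shows that, with 2,4-difluorobenzyl present, this pair cannot be told apart, which leaves compound 1 and compound 4 together at the low end of the series. No measurement available here offers an explanation for either result.

A single fluorine on the benzyl group, or a chlorine or methoxy group in its place, could show whether the drop needs both fluorines or also appears with other substituents on the ring. As far as these compounds go, it also remains open whether the same fluorine change would lower the number with phenyl in place of methyl on the aromatic carbon, as in compound 2, and whether an amine or a longer chain at the benzyl position would give clear inhibition.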